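The source may report more compounds than this note shows. Statements on the series, on what has been measured and on what is new or still open speak of the compounds shown alone.

Compound 1 `Nc1ncnc2c1c(Oc1cc(C(F)(F)F)ccn1)nn2C1CC1`: > 2.41 h
Compound 2 `Nc1ncnc2c1c(Oc1cc(C(F)(F)F)ccn1)nn2[C@H]1CC[C@@H](CO)CC1`: 0.108 h
Compound 3 `Nc1ncnc2c1c(Oc1cc(C(F)(F)F)ccn1)nn2[C@H]1C[C@H](F)C1`: 0.883 h

In an ADME assay on microsomes from liver (Mus musculus) for metabolic stability, read by LC-MS, using NADPH, with a stated time of 10 min, tested at 10 uM (on this read-out lower numbers stand for a shorter-lived compound and higher numbers for a longer-lived compound), compound 3 gives 0.883 h, the higher of the two exact numbers. The entry for compound 1 is a limit of the assay, not a number. Compound 4 `CO[C@H]1CC[C@H](n2nc(Oc3cc(C(F)(F)F)ccn3)c3c(N)ncnc32)CC1` differs from compound 3 by one change, 4-methoxycyclohexyl in place of 3-fluorocyclobutyl on an aromatic nitrogen.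

Within the data shown here, three measured steps bear on this change, all at this same nitrogen: an 8.2-fold higher number from compound 2 to compound 3 (0.91 log units; beyond the scatter), an at least 22-fold lower number from compound 1 to compound 2 (1.34 log units; beyond the scatter) and an at least 2.7-fold lower number from compound 1 to compound 3 (0.43 log units; beyond the scatter). The closest guide is compound 2, at 0.108 h, which also carries a six-membered ring. A fall is therefore expected, and the estimated step is a 5.9-fold lower number from compound 3 to compound 4 (0.77 log units; beyond the scatter). For compound 4 the expected half-life is 0.15 h, estimated to lie between 0.06 h and 0.4 h.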

Compound 4, half-life: 0.217 h
Beside the measured number, compound 4's estimate is 1.4-fold (0.16 log units) below it; the measured number falls inside the stated range.
By their numbers in this assay, from the lowest: compounds 2 and 4 (each within the scatter of the next); then compound 3. At a limit, above all of these: compound 1.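

A second cyclohexyl group with a different substituent again gives a short half-life, with a 4.1-fold lower number from compound 3 to compound 4 (0.61 log units; beyond the scatter). Methoxy and hydroxymethyl on the cyclohexyl ring cannot be told apart here, with a 2.0-fold higher number from compound 2 to compound 4 (0.30 log units; within the scatter). The entry for compound 1 is a limit of the assay, not a number, and the step of an at least 11-fold lower number from compound 1 to compound 4 (1.04 log units; beyond the scatter) is read against it: the limit of > 2.41 h in this assay, at which 1 of the 4 values shown sits.

On these data alone, it remains open whether the size of the ring or the group it carries sets the half-life. A plain cyclohexyl or a 4-aminocyclohexyl group would help separate the two.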